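The source may hold more compounds than are shown below. What is called first, only, known or untested is meant among the compounds shown, and "the series" means these compounds.

The shared core is seen in compound 1 `O=C(Nc1nnc(-c2ccc3c(c2)OCCO3)s1)c1ccccc1`. In a functional assay on HeLa cells (Homo sapiens) for antiproliferative activity, read by MTT assay, with a stated time of 48 h (on this read-out lower numbers stand for an effect already at smaller amounts and higher numbers for an effect only at larger amounts of compound), compound 1 gives > 100 ug/mL, which is a limit of the assay and not a number. Compound 2 `O=C(/C=C/c1ccccc1)Nc1nnc(-c2ccc3c(c2)OCCO3)s1` carries 2-phenylethenyl in place of phenyl on the carbonyl carbon. In this assay compound 2 likewise gives > 100 ug/mL, again a limit rather than a number. The step that the two limits leave unreadable from compound 1 to compound 2 therefore cannot be read; the two values share (the limit of > 100 ug/mL in this assay, at which 2 of the 2 values shown sit).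

Compound 3 `Cc1ccc(C(=O)Nc2nnc(-c3ccc4c(c3)OCCO4)s2)cn1` differs from compound 1 as follows: 6-methylpyridin-3-yl in place of phenyl on a carbonyl carbon. Within the data shown here, no measured step covers a ring of this kind, and the only measured step, from phenyl to 2-phenylethenyl, is itself unreadable. Among the measured compounds shown here, compound 1 stands at a limit in this assay, with no number for it, and the one further value shown is a limit too. For the measured compounds named here, there is thus no measured step to carry over and no ground to expect a change that could be read. The step expected, a step that the limit leaves unreadable from compound 1 to compound 3, is one that stays within the unreadable range. Compound 3 is accordingly expected to give about 130 ug/mL in this assay, within a range from 50 ug/mL to 350 ug/mL, most likely reported once more only as a limit.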

Compound 3, half-maximal effective concentration: > 100 ug/mL
Compound 3: no number, only a limit; the forecaster's own chance of this, stated with the estimate: 80%; the middle value lies beyond the limit too.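

In this assay compound 3 gives > 100 ug/mL as a limit of the assay and not a number. Among these compounds, no step among compound 1, compound 2 and compound 3 can be read: the limit of > 100 ug/mL in this assay, at which 3 of the 3 values shown sit. The compounds shown leave open whether any group on the carbonyl carbon of the shared core gives a number rather than a limit.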